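Working notes: from compound 3 to compound 4

The compounds below may be only part of what the source reports. "The series", "measured", "known", "first", "only" and "open" are said of these compounds alone.

- compound 1 `CC(=O)n1nc(NC(=O)c2ccccc2)c2c1CN(C(=O)c1cccc(F)c1)C2` gives 21900 nM
- compound 2 `CC(=O)n1nc(NC(=O)c2ccccc2)c2c1CN(C(=O)c1cccc(Cl)c1)C2` gives 17400 nM
- compound 3 `CC(=O)n1nc(NC(=O)c2ccccc2)c2c1CN(S(=O)(=O)N(C)C)C2` gives 35300 nM

Among the compounds with values here, all three values come from a functional assay on HCT-116 cells (Homo sapiens) for cytotoxicity, read by sulforhodamine B assay, with a stated time of 48 h (a lower number here means a stronger inhibitor, a higher number a weaker inhibitor), and are the only evidence available. The data show a 2.0-fold higher number from compound 2 to compound 3 (0.31 log units; beyond the scatter) and a 1.6-fold higher number from compound 1 to compound 3 (0.21 log units; within the scatter) as well, so compound 3 separates only from compound 2.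

Compound 4 `CC(=O)n1nc(NC(=O)c2ccccc2)c2c1CN(C(=O)c1ccncc1)C2` comes next, with (pyridin-4-yl)carbonyl in place of dimethylsulfamoyl on an amine nitrogen in a ring as the count of the change: (pyridin-4-yl)carbonyl in place of dimethylsulfamoyl on an amine nitrogen in a ring. Those two steps run the opposite way, from an aromatic carbonyl to dimethylsulfamoyl, and a 1.3-fold lower number from compound 1 to compound 2 (0.10 log units; within the scatter) came with the swap of chloro for fluoro. Within the data shown here, no measured compound carries the (pyridin-4-yl)carbonyl group. Read against compound 1 and compound 2 through those steps, the expected change is a 1.5-fold lower number from compound 3 to compound 4 (0.17 log units; within the scatter) as a small move within the scatter. For compound 4 the estimated value is 24000 nM with an expected range from 11000 nM to 50000 nM in this assay for now.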

Compound 4, half-maximal inhibitory concentration: 10000 nM
Compound 4: the middle estimate sits 2.4-fold (0.38 log units) above what was measured, outside the stated range (below it).
By their numbers in this assay, from the lowest: compounds 4, 2, 1 and 3 (each within the scatter of the next, the first and the last beyond it).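

In this assay, the amine nitrogen in a ring now shows a step beyond the scatter in favour of (pyridin-4-yl)carbonyl over dimethylsulfamoyl, with a 3.5-fold lower number from compound 3 to compound 4 (0.55 log units; beyond the scatter), and pyridin-4-yl also separates from 3-fluorophenyl on the carbonyl carbon, with a 2.2-fold lower number from compound 1 to compound 4 (0.34 log units; beyond the scatter). It does not separate from 3-chlorophenyl there, with a 1.7-fold lower number from compound 2 to compound 4 (0.24 log units; within the scatter), so the aromatic carbonyl groups do not form a clear order. No available evidence explains these steps.

Still open, as far as these compounds go, is whether an amine or a carboxylic acid carried on the pyridine ring would move the number further at this position.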